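A few compounds are considered here, and "the series" means these few. Any claim that something is new, unique, unknown or untested is made for them only; others in the source may bear on it.

Working notes on the series

Of the compounds shown here, two have been measured in an ADME assay on HEK293 cells (Homo sapiens) for cytotoxicity, read by resazurin assay, with a stated time of 48 h; on this read-out higher numbers stand for lower toxicity in this test and lower numbers for higher toxicity in this test. Compound 1 `Cc1ccc(S(=O)(=O)Nc2ccc(-c3nc4ccccc4o3)cc2)cc1` gives 88000 nM in this assay. Compound 2 `O=S(=O)(Nc1ccc2oc(-c3ccccc3)nc2c1)c1ccc(Cl)c(Cl)c1` gives 71000 nM in this assay. The number for compound 1 is the higher of the two, but its gap to compound 2 lies within the scatter, so the two compounds cannot be told apart on this read-out; both sit in the same weakly cytotoxic range.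

Compound 3 `COc1ccc(S(=O)(=O)Nc2ccc(-c3nc4ccccc4o3)cc2)cc1` has not yet been measured in this assay. It differs from compound 1 as follows: methoxy in place of methyl on an aromatic carbon

Within the data shown here, no step between measured compounds covers this change, so nothing shows how the replacement of methyl by methoxy acts on cytotoxicity. The two measured compounds differ from one another in several places at once and still fall within the scatter of each other, which gives no sign that the read-out responds sharply to substitution of this kind.

For compound 3 the step from compound 1 is expected to be a 1.0-fold lower number from compound 1 to compound 3 (0.02 log units; within the scatter), that is, no change beyond the scatter in either direction. Compound 3 is therefore estimated at 85000 nM in this assay, with a range from 40000 nM to 180000 nM.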

Compound 3, half-maximal cytotoxic concentration: > 100000 nM
Compound 3: only a limit was reported; the forecaster's own chance of this, stated with the estimate: 25%; middle value at least 1.1-fold (0.07 log units) from the limit.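

In this assay compound 3 gives > 100000 nM, which is a limit of the assay and not a number. Methoxy in place of methyl, on an aromatic carbon para to a large group, gives an at least 1.1-fold higher number from compound 1 to compound 3 (0.05 log units; that floor lies within the scatter). This is the first step read at this position: going from 4-methylphenyl to 4-methoxyphenyl, with one more heavy atom and one hydrogen-bond acceptor entering, brings no fall in the number on this read-out, and any rise beyond the scatter can be neither claimed nor excluded, the true size of the step remaining unread on this ground: the limit of > 100000 nM in this assay, at which 1 of the 3 values shown sits.

Going by these compounds, what an amine or a carboxylic acid would do on this aromatic carbon stays open, as does a longer chain such as ethoxy in place of methoxy. Also open is whether the same replacement would give a similar step on the core of compound 2, since the compounds shown hold only this single step, on the core of compound 1.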